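The compounds below may be only part of what the source reports. "The series", "measured", "known", "first", "only" and "open" are said of these compounds alone.

For the measured compounds named here, compound 1 `CCOC(=O)c1c(-c2cccc(C)c2)csc1N` is one of two compounds measured in an assay on isolated protein for inhibition of protein kinase C zeta type (Homo sapiens), with stated times of 1 h and 2.5 min, tested at 30 uM; on this read-out lower numbers stand for less inhibition and higher numbers for more inhibition at the one concentration tested (going by the name of the read-out). In this assay, going by the values given here, compound 1 gives 77%, the lower of the two numbers, while compound 2 `CCOC(=O)c1c(-c2cccc(OC)c2)csc1N` gives 82%; the step of a number 5 percentage points higher from compound 1 to compound 2 (within the scatter) is the only one recorded, and it is within the scatter, so compound 1 stands essentially level with its single neighbour. Compound 3 `Cc1cccc(-c2csc(N)c2C(=O)OCc2ccccc2)c1` has not yet been measured. It differs from compound 1 by phenyl in place of methyl on a saturated chain carbon bound to an oxygen next to a carbonyl group. Among the compounds with values here, the one recorded step concerns a group on the aromatic ring, not the saturated chain carbon bound to an oxygen next to a carbonyl group, so no measured step bears directly on this change. Within the data shown here, with the only known step being small, a step of size a number 3 percentage points lower from compound 1 to compound 3 (within the scatter) in this assay is expected, meaning no movement beyond the scatter. Compound 3 is estimated at 74%, between 52% and 90%.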

Compound 3, a percentage reported as inhibition, at one concentration (the size of the read-out at that concentration, not a potency): 68%
Compound 3: middle estimate off by 6 percentage points, on the high side, within the range that was stated.
By their numbers in this assay, from the lowest: compounds 3, 1 and 2 (each within the scatter of the next, the first and the last beyond it).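

The first change away from the aromatic ring, phenyl in place of methyl on a saturated chain carbon bound to an oxygen next to a carbonyl group, gives a number 9 percentage points lower from compound 1 to compound 3 (within the scatter) in this assay. For the compounds shown here, this position, which the earlier compounds left untouched, therefore carries benzyl in place of ethyl, with its added six-membered aromatic ring of carbon only, without a move beyond the scatter. Nothing measured here speaks to the reason for this reading.

As far as these compounds go, whether a carboxylic acid, an amide or a longer chain ending in phenyl would hold the number at this place remains open. So does whether a fluorine or a methoxy on the new phenyl ring would move it, and whether methoxy in place of methyl on the other aromatic ring would read the same with benzyl present.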